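Indazolyl-pyrimidine anilines: extending the ring-nitrogen alkyl

The compounds below may be only part of what the source reports. "The series", "measured", "known", "first", "only" and "open" are said of these compounds alone.

Measured compounds and values:
compound 1, `Cc1cccc(Nc2nccc(-c3nn(C)c4ccccc34)n2)c1`: 9150 nM
compound 2, `Cn1nc(-c2ccnc(Nc3cccc([N+](=O)[O-])c3)n2)c2ccccc21`: 580 nM

Both numbers come from a functional assay on MCF7 cells (Homo sapiens) for antiproliferative activity, read by MTT assay, with a stated time of 72 h; on this read-out lower numbers stand for stronger inhibition of growth and higher numbers for weaker inhibition of growth. Compound 2 stands lowest of the two measured numbers; its nearest neighbour is compound 1, separated by a 16-fold lower number from compound 1 to compound 2 (1.20 log units; beyond the scatter). That single step concerns the substituent on the aniline carbon (nitro in place of methyl on an aromatic carbon) and nothing else.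

Compound 3, `CCn1nc(-c2ccnc(Nc3cccc([N+](=O)[O-])c3)n2)c2ccccc21`, is not yet measured in this assay. It differs from compound 2 by methyl in place of hydrogen on a saturated chain carbon bound to an aromatic nitrogen, which the next bond out reads as methyl to ethyl on the alkylated nitrogen of the shared core. For the measured compounds named here, no measured pair varies this nitrogen substituent; the only recorded step, from the aniline change, does not bear on it. With nothing in the series speaking for a change at this position, the expectation is a step not beyond the scatter, i.e. a 1.0-fold higher number from compound 2 to compound 3 (0.01 log units; within the scatter).

Compound 3 is therefore estimated at 600 nM in this assay, with a range from 250 nM to 1500 nM.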

Compound 3, concentration for 50% growth inhibition: 2310 nM
Estimate against measurement, compound 3: 3.9-fold (0.59 log units) below, and the stated range ends below it.
By their numbers in this assay, from the lowest: compound 2; then compound 3; then compound 1.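

The alkyl group on the ring nitrogen is not a silent position: in this assay, methyl to ethyl gives a 4.0-fold higher number from compound 2 to compound 3 (0.60 log units; beyond the scatter), so one added carbon at this place is enough to move the read-out, something the aniline step could not show. Here the direction is toward weaker inhibition of growth with the longer group, and compound 2, carrying methyl, keeps the lowest number of the three; one pair gives a direction for this single change, not a trend with chain length. Nothing on hand accounts for the size or direction of this step.

The compounds shown leave open whether the number keeps rising with a propyl group or a longer chain, and whether hydrogen on this nitrogen, a cyclopropyl group or a chain ending in an amine would fall below or above the methyl compound. They also leave open whether the same step would appear with methyl rather than nitro on the aniline carbon.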